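The source may report more compounds than this note shows. Statements on the series, on what has been measured and on what is new or still open speak of the compounds shown alone.

Measured compounds:
- compound 1, `O=C(Nc1cccc(-n2cc(-c3ccncc3)c(-c3cc(O)cc(Cl)c3)n2)c1)Nc1ccc(Cl)c(C(F)(F)F)c1`: 102%
- compound 2, `O=C(Nc1cccc(-n2cc(-c3ccncc3)c(-c3cc(O)cc(Cl)c3)n2)c1)Nc1ccc(Cl)c(Cl)c1`: 100%
- compound 3, `COc1cc(Cl)cc(-c2nn(-c3cccc(NC(=O)Nc4cc(C(F)(F)F)cc(C(F)(F)F)c4)c3)cc2-c2ccncc2)c1`: 97%

All three were tested in a functional assay on CAKI-1 cells (Homo sapiens) for inhibition, read by sulforhodamine B assay, with a stated time of 48 h, tested at 0.01 uM; on this read-out higher numbers stand for a weaker effect at the one concentration tested and lower numbers for a stronger effect. On that read-out compound 1 gives 102%, compound 2 gives 100% and compound 3 gives 97%, and the three numbers sit within the scatter of one another, so none of them can be set apart from the others. Among the compounds with values here, the one step that can be followed, a number 2 percentage points lower from compound 1 to compound 2 (within the scatter), changes a group on the same ring that the present step concerns and leaves the read-out essentially unchanged.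

Compound 4, `COc1cc(Cl)cc(-c2nn(-c3cccc(NC(=O)Nc4cccc(C(F)(F)F)c4)c3)cc2-c2ccncc2)c1`, differs from compound 3 by hydrogen in place of trifluoromethyl on an aromatic carbon. Within the data shown here, the only comparable step, from compound 1 to compound 2, stayed within the scatter, and no measured pair shows the loss of a trifluoromethyl group directly. Compound 4 is therefore expected to give a number close to that of compound 3, with the expected step of a number 3 percentage points higher from compound 3 to compound 4 (within the scatter) staying within the scatter. The expected value for compound 4 is 100%, within a range from 92% to 108%.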

Compound 4, a percentage reported as activity, at one concentration (the size of the read-out at that concentration, not a potency): 102%
Estimate against measurement, compound 4: 2 percentage points below, within the range that was stated.
By their numbers in this assay, from the lowest: compounds 3, 2, 1 and 4 (each within the scatter of the next).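

Within the data shown here, putting hydrogen in place of trifluoromethyl on this aromatic carbon gives, in this assay, a number 5 percentage points higher from compound 3 to compound 4 (within the scatter), which is the first direct reading of the loss of this group rather than its exchange for chloro. At this one concentration, the read-out therefore does not separate the ring with the additional trifluoromethyl group from the ring with hydrogen at this place, and the other trifluoromethyl group remains in both compounds. No measured information bears on why the read-out behaves this way.

The compounds shown leave open whether an amine or a carboxylic acid at this position would give a step beyond the scatter. They also leave open whether the ring would read the same with hydrogen in place of the remaining trifluoromethyl group, or whether this step would read the same at a higher concentration.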